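This account rests on a few compounds, and the source may have more. Where it says the series, first, only, none or still open, it means among the compounds named here.

Measured so far:
compound 1, `O=c1ccn(COCCO)c(=O)[nH]1` — in a functional assay on L1210 cells (Mus musculus) for inhibition (a lower number here means a stronger inhibitor, a higher number a weaker inhibitor), compound 1 gives > 1000 ug/mL
compound 2, `Nc1nc(=O)n(COCCO)cc1[N+](=O)[O-]` — in this assay compound 2 gives > 500 ug/mL

Neither of the two values is a number; each is a limit of the assay, meaning the compound showed no measurable inhibition up to the highest concentration tested. Compound 1 stands at the limit of > 1000 ug/mL in this assay, at which 1 of the 2 values shown sits. Compound 2 stands at the limit of > 500 ug/mL in this assay, at which 1 of the 2 values shown sits. So for compound 1 the only thing known is that it is a weak inhibitor, with no number to anchor a comparison.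

Compound 3, `O=c1[nH]c(=O)n(COCCO)cc1/C=C/Br`, has not been measured. It differs from compound 1 in one place: 2-bromoethenyl in place of hydrogen on an aromatic carbon.

Within the data shown here, no step between two measured compounds with a known number exists here, so the effect of this change cannot be read from the data. Compound 1 itself only shows a limit, and the outcome for compound 3 can be stated as an expectation alone. The expected step is an at least 2.5-fold lower number from compound 1 to compound 3 (0.39 log units; beyond the scatter) in this assay, which may amount to nothing beyond the scatter. Compound 3 is expected to give about 400 ug/mL in this assay, within a range from 100 ug/mL to 1000 ug/mL, and quite possibly again only as a limit.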

Compound 3, concentration for 50% inhibition: > 1000 ug/mL
Compound 3: only a limit was reported; the forecaster's own chance of this, stated with the estimate: 60%; middle value at least 2.5-fold (0.39 log units) away from the limit.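

Compound 1 and compound 3 each give a limit of the assay rather than a number, and no step can be read between them because both sit at the same limit: the limit of > 1000 ug/mL in this assay, at which 2 of the 3 values shown sit.

The compounds shown leave open whether 2-bromoethenyl in place of hydrogen on an aromatic carbon changes inhibition at all in this assay.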